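From Compound 1 to Compound 4 in Jurkat Cells

The source may hold more compounds than are shown below. What is called first, only, known or untested is meant among the compounds shown, and "the series" means these compounds.

Compound 1, `CCOC(=O)c1c(C)noc1OCC(=O)[C@H](CC(=O)O)NC(=O)[C@@H](NC(=O)COc1cccc2ccccc12)C(C)C`, gives in a functional assay on Jurkat cells (Homo sapiens) for inhibition (a higher number here means a weaker inhibitor, a lower number a stronger inhibitor), a value of > 200000 nM, which is a limit of the assay.
Compound 2, `COC(=O)c1cc(OCC(=O)[C@H](CC(=O)O)NC(=O)[C@@H](NC(=O)COc2cccc3ccccc23)C(C)C)no1`, gives in this assay a value of 71000 nM.
Compound 3, `CC(C)[C@H](NC(=O)COc1cccc2ccccc12)C(=O)N[C@@H](CC(=O)O)C(=O)COc1ccncn1`, gives in this assay a value of > 200000 nM, which is again a limit.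

Compound 1 therefore stands at the weak end of what has been measured, and its value is only a limit (the limit of > 200000 nM in this assay, at which 2 of the 3 values shown sit). The compound not yet measured is compound 4, `CC(C)[C@H](NC(=O)COc1cccc2ccccc12)C(=O)N[C@@H](CC(=O)O)C(=O)COc1cc(C(F)(F)F)ncn1`. It differs from compound 1 in one place: 6-(trifluoromethyl)pyrimidin-4-yl in place of 4-(ethoxycarbonyl)-3-methyl-1,2-oxazol-5-yl on an oxygen on a saturated carbon.

Going by the values given here, two measured steps bear on this. The step that the two limits leave unreadable from compound 1 to compound 3 puts a pyrimidin-4-yl at the same oxygen and cannot be read, since both ends are limits. The step of an at least 2.8-fold higher number from compound 2 to compound 3 (0.44 log units; beyond the scatter) shows that the pyrimidin-4-yl gives a weaker inhibitor than the 5-(methoxycarbonyl)-1,2-oxazol-3-yl. Compound 4 carries a 6-(trifluoromethyl)pyrimidin-4-yl, closest in kind to compound 3, so no step beyond the scatter is expected from compound 1, and the result is most likely another limit.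

The value of compound 4 in this assay is estimated at 200000 nM, between 60000 nM and 600000 nM, which means an expected step of a number no higher from compound 1 to compound 4 (the limit leaves the size open).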

Compound 4, half-maximal inhibitory concentration: > 200000 nM
Compound 4: only a limit was reported; the forecaster's own chance of this, stated with the estimate: 65%; the middle value lies on the limit itself.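

Compared with the 5-(methoxycarbonyl)-1,2-oxazol-3-yl, the 6-(trifluoromethyl)pyrimidin-4-yl on this oxygen gives an at least 2.8-fold higher number from compound 2 to compound 4 (0.44 log units; beyond the scatter), and adding a trifluoromethyl to the pyrimidin-4-yl does not reach the value of compound 2. The steps to compound 4 from compound 1 and from compound 3 cannot be read, as both ends of each are limits, and any effect of trifluoromethyl in place of hydrogen stays hidden. Of the groups shown on this oxygen, only the 5-(methoxycarbonyl)-1,2-oxazol-3-yl gives a number, and the others all stop at the same limit: the limit of > 200000 nM in this assay, at which 3 of the 4 values shown sit.

The compounds shown leave open whether the methoxycarbonyl or the ring that carries it accounts for the measurable value of compound 2, a question that a pyrimidin-4-yl bearing a methoxycarbonyl, or a 1,2-oxazol-3-yl bearing a carboxylic acid or an amine in its place, could address. Going by these compounds, how far apart compound 1, compound 3 and compound 4 lie in this assay also stays open, as all three results are limits.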